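The source may hold more compounds than are shown below. What is called first, only, known or untested is meant among the compounds shown, and "the series" means these compounds.

Of the compounds shown here, two measured so far share a core and differ only in the aromatic ring on the amide carbonyl. In a functional assay on KM12 cells (Homo sapiens) for inhibition, read by colorimetric assay and sulforhodamine B assay, with a stated time of 48 h (a higher number here means a weaker inhibitor of growth, a lower number a stronger inhibitor of growth), compound 1 `CCCCCCCCCCCC[C@@H](O)[C@H]1CC[C@H]([C@H](O)CCCCCCCCCCNC(=O)c2cccs2)O1` gives 3090 nM, whereas compound 2 `CCCCCCCCCCCC[C@@H](O)[C@H]1CC[C@H]([C@H](O)CCCCCCCCCCNC(=O)c2ccco2)O1` gives 100000 nM. That is the higher of the two numbers, which makes compound 2 the weaker growth inhibitor of the pair.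

Compound 3 `CCCCCCCCCCCC[C@@H](O)[C@H]1CC[C@H]([C@H](O)CCCCCCCCCCNC(=O)c2ccoc2)O1` has the same atoms as compound 2, joined differently, with furan-3-yl in place of furan-2-yl on a carbonyl carbon. Among the compounds with values here, only one measured step bears on this change: a 32-fold higher number from compound 1 to compound 2 (1.51 log units; beyond the scatter). This step is large and beyond the scatter, so a swap of the ring at this place can move the number a long way. However, it replaces one ring with another, and no measurement yet shows what a change in the ring's point of attachment does. Within the data shown here, with compound 2 at the higher end of only two numbers, a moderate downward move seems more likely than a further rise. The expected change is a 5.0-fold lower number from compound 2 to compound 3 (0.70 log units; beyond the scatter), a loose estimate. In this assay, compound 3 is expected at 20000 nM, within an estimated range of 3000 nM to 100000 nM.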

Compound 3, concentration for 50% growth inhibition: 100000 nM
Compound 3: the middle estimate sits 5.0-fold (0.70 log units) below what was measured; the measured number falls inside the stated range.
By their numbers in this assay, from the lowest: compound 1; then compounds 2 and 3 (each within the scatter of the next).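

Furan-3-yl in place of furan-2-yl on the carbonyl carbon is the first change here that keeps the ring and moves only its point of attachment, and in this assay it gives no change at the digits printed from compound 2 to compound 3 (within the scatter), so at this place, between these two compounds, the point of attachment of the furan ring makes no visible difference. Replacing thiophen-2-yl with the other furan gives a 32-fold higher number from compound 1 to compound 3 (1.51 log units; beyond the scatter), so the large gap first seen with compound 2 appears with both furan rings, and compound 1 remains apart from them. No measurement at hand gives a reason for either result.

Going by these compounds, it remains open whether thiophen-3-yl would give a number near that of compound 1 or near those of compound 2 and compound 3, which would show whether point of attachment matters for the sulfur-containing ring even though it shows no effect for the furan rings. A phenyl ring or a pyridine ring on the same carbonyl carbon would also show whether thiophen-2-yl is unusual among aromatic rings at this place or whether the furan rings are.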